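The source may hold more compounds than are shown below. What is called first, only, known or untested is meant among the compounds shown, and "the series" means these compounds.

Measured so far:
Compound 1 `Nc1cc(N)c2nc(-c3ccccc3)c(NCc3ccc(Cl)c(Cl)c3)nc2c1` — 19100 nM
Compound 2 `COc1ccc(CNc2nc3cc(N)cc(N)c3nc2-c2ccccc2)cc1OC` — 83200 nM

Going by the values given here, in a functional assay on PC-3 cells (Homo sapiens) for inhibition, read by sulforhodamine B assay, with a stated time of 48 h (a lower number here means that less compound is tolerated, a higher number that more compound is tolerated), compound 2 stands highest of the two; the only measured step is a 4.4-fold higher number from compound 1 to compound 2 (0.64 log units; beyond the scatter). Compound 3 `Nc1cc(N)c2nc(-c3ccccc3)c(NCc3ccc(F)cc3)nc2c1` differs from compound 2 by 4-fluorophenyl in place of 3,4-dimethoxyphenyl on a saturated chain carbon bound to a nitrogen on an aromatic ring. That single step bears on it in reverse: a halogen-bearing aryl gave the lower number in compound 1, so a modest move back toward it is expected, a 2.6-fold lower number from compound 2 to compound 3 (0.41 log units; beyond the scatter), though with one step to go on the size is uncertain. Compound 3 is estimated at 32000 nM, between 11000 nM and 90000 nM.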

Compound 3, concentration lethal to 50% of the cells: < 100000 nM
Compound 3 was reported as a limit; the forecaster's own chance of this, stated with the estimate: 10%; the middle value does not contradict the limit.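

Compound 3 gives < 100000 nM, which is a limit of the assay and not a number. Going by these compounds alone, no step to compound 3 from compound 1 or compound 2 can be read. The compounds shown leave open how 4-fluorophenyl compares with 3,4-dichlorophenyl and 3,4-dimethoxyphenyl.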